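Shrinking the sulfur substituent on a nucleoside purine scaffold

This account rests on a few compounds, and the source may have more. Where it says the series, first, only, none or still open, it means among the compounds named here.

Compound 1 `OC[C@H]1O[C@@H](n2cnc3c(SCC4CCCCC4)ncnc32)[C@H](O)[C@@H]1O` gives 1550 nM. Compound 2 `Nc1nc(SCc2cccc(Br)c2)c2ncn([C@@H]3O[C@H](CO)[C@@H](O)[C@H]3O)c2n1` gives 2880 nM. Compound 3 `CCCC(C)n1cnc2c(SCc3ccccn3)nc(N)nc21` gives 41700 nM.

These values come from an assay on isolated protein for binding affinity to Equilibrative nucleoside transporter 1 (Homo sapiens); a lower number here means a stronger inhibitor, a higher number a weaker inhibitor. Among the three measured compounds, compound 2 has the second highest number; compound 1 sits within the scatter of it, while compound 3 lies well beyond the scatter at a far higher number, so only compound 3 is clearly the weaker inhibitor of the set.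

Compound 4 `CSc1nc(N)nc2c1ncn2[C@@H]1O[C@H](CO)[C@@H](O)[C@H]1O` differs from compound 2 in one place: hydrogen in place of 3-bromophenyl on a saturated chain carbon bound to a sulfur. For the measured compounds named here, no measured pair here isolates this change, so its effect must be expected rather than read off. Removing the whole 3-bromophenyl group is a large loss of structure, and the step of a 10-fold higher number from compound 2 to compound 4 (1.02 log units; beyond the scatter) is expected to be a marked weakening, beyond the scatter. Compound 4 is therefore estimated at 30000 nM, with a plausible range from 5000 nM to 200000 nM.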

Compound 4, half-maximal inhibitory concentration: 204000 nM
Estimate against measurement, compound 4: 6.8-fold (0.83 log units) below; measured number above the stated range.
By their numbers in this assay, from the lowest: compounds 1 and 2 (each within the scatter of the next); then compound 3; then compound 4.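

In this assay, putting hydrogen in place of 3-bromophenyl on a saturated chain carbon bound to a sulfur gives a 71-fold higher number from compound 2 to compound 4 (1.85 log units; beyond the scatter) and turns a (3-bromobenzyl)sulfanyl group into a methylsulfanyl group. For the compounds shown here, this is the first pair here that differs in one place, and it shows that the strength of compound 2 depends heavily on the part removed. Nothing measured here accounts for the loss.

The compounds shown leave open whether the bromine or the phenyl carries the effect, which an unsubstituted benzyl group could separate. They also leave open whether a longer chain such as butyl could recover any strength.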